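Allyl for ethyl on the ring nitrogen in the aorta series

A few compounds are considered here, and "the series" means these few. Any claim that something is new, unique, unknown or untested is made for them only; others in the source may bear on it.

Compound 1 `C=CCn1nc(Cc2ccc(Cl)cc2)c2ccccc2c1=O` and compound 2 `CCn1nc(Cc2ccc(Cl)cc2)c2ccccc2c1=O` share one core and differ only by vinyl in place of methyl on a saturated chain carbon bound to an aromatic nitrogen. In a functional assay on aorta with Alpha-1D adrenergic receptor (Rattus norvegicus) as the target (on this read-out higher numbers stand for an effect only at larger amounts of compound and lower numbers for an effect already at smaller amounts), compound 2 gives 1300 nM, and compound 1 gives 2600 nM; the step of a 2.0-fold higher number from compound 2 to compound 1 (0.30 log units; within the scatter). Compound 3 `CCn1nc(Cc2ccc(OC)c(OC)c2)c2ccccc2c1=O` sits on a second core, and the difference between the two cores is not broken down here. In this assay compound 3 gives 5300 nM, the highest number of the three measured. Compound 4 `C=CCn1nc(Cc2ccc(OC)c(OC)c2)c2ccccc2c1=O` is not yet measured and differs from compound 3 by vinyl in place of methyl on a saturated chain carbon bound to an aromatic nitrogen, the same change that separates compound 2 from compound 1. A step of about the same size is expected, a 1.9-fold higher number from compound 3 to compound 4 (0.28 log units; within the scatter), because a 2.0-fold higher number from compound 2 to compound 1 (0.30 log units; within the scatter) and both changes sit at the same place. Compound 4 is therefore expected to give 10000 nM, estimated between 4000 nM and 25000 nM.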

Compound 4, half-maximal effective concentration: 9800 nM
For compound 4 the middle estimate is 1.0-fold (0.01 log units) above the measured one; low and high end bracket the measured number.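

On the core of compound 3, ethyl to allyl gives a 1.8-fold higher number from compound 3 to compound 4 (0.27 log units; within the scatter) in this assay. Set beside the earlier step, the change carries from one core to the other with no detectable difference: the same change on two cores in this assay, a 2.0-fold higher number (0.30 log units; within the scatter) from compound 2 to compound 1 and a 1.8-fold higher number (0.27 log units; within the scatter) from compound 3 to compound 4, 1.1-fold (0.03 log units) apart, within the scatter of two such steps

Each step lies within the scatter on its own, so the agreement shows no clear effect of the change on either core, and two cores say nothing about how it behaves on any other core.

Only ethyl and allyl are shown at this place, so it remains open whether a longer chain such as butyl, or a chain ending in an amine or a carboxylic acid, would shift the number beyond the scatter. Also open, from the compounds shown here alone, is how the change reads on a core carrying a nitrile in place of the chlorine.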